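The compounds below may be only part of what the source reports. "The series", "measured", "known", "first", "only" and "open" are said of these compounds alone.

Series in an ADME assay on CCRF-CEM cells (Homo sapiens) for cytotoxicity, with a stated time of 5 days; on this read-out higher numbers stand for weaker inhibition and lower numbers for stronger inhibition:
Compound 1 `C=CCNc1nc(N)nc2c1ncn2[C@H]1C[C@H](N=[N+]=[N-])[C@@H](CO)O1`: > 100000 nM, a limit.
Compound 2 `CN(C)c1nc(N)nc2c1ncn2[C@H]1C[C@H](N=[N+]=[N-])[C@@H](CO)O1`: > 100000 nM, a limit.
Compound 3 `CC(CO)Nc1nc(N)nc2c1ncn2[C@H]1C[C@H](N=[N+]=[N-])[C@@H](CO)O1`: > 100000 nM, a limit.

Compound 3 gives no number and stands at the limit of > 100000 nM in this assay, at which 3 of the 3 values shown sit. Compound 4 `C#CCNc1nc(N)nc2c1ncn2[C@H]1C[C@H](N=[N+]=[N-])[C@@H](CO)O1` differs from it by propargyl in place of 1-(hydroxymethyl)ethyl on a nitrogen on an aromatic ring, with propargyl in place of 1-(hydroxymethyl)ethyl on a nitrogen on an aromatic ring. Among the measured compounds shown here, the steps that bear on this change are a step that the two limits leave unreadable from compound 1 to compound 3 and a step that the two limits leave unreadable from compound 2 to compound 3. Neither has a size that can be carried over. With every measured compound at a limit, a number no higher from compound 3 to compound 4 (the limit leaves the size open) is expected to stay within the scatter, and a limit is the likeliest report. The estimate for compound 4 is 100000 nM, with an estimated range of 30000 nM to 200000 nM.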

Compound 4, half-maximal inhibitory concentration: > 100000 nM
Compound 4: a limit, no number (the forecaster's own chance of this, stated with the estimate: 80%); the middle value lies on the limit itself.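

No step can be read among compound 1, compound 2, compound 3 and compound 4 in this assay, as each result is a limit: the limit of > 100000 nM in this assay, at which 4 of the 4 values shown sit.

The compounds shown leave open how these groups on the shared core rank against one another.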